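The source may hold more compounds than are shown below. What is called first, only, known or untested is meant among the compounds shown, and "the series" means these compounds.

Working notes on the series, read in an ADME assay on microsomes from liver (Homo sapiens) for metabolic stability; on this read-out lower numbers stand for slow clearance and higher numbers for fast clearance.

Of the compounds shown here, three have numbers so far. Compound 1 `CNC(=O)c1sc(N2CC3CC2(CNC(=O)c2c[nH]c4ncc(C(F)(F)F)cc24)C3)nc1C(F)(F)F` gives 130 mL.min-1.g-1 in this assay. Compound 2 `COc1cc2c(Nc3cnc(OCCCC4CCCC4)nc3)ncnc2cc1OCCCN1CCCCC1` gives 96 mL.min-1.g-1, and compound 1 and compound 2 sit within the scatter of each other, so neither is ranked above the other. Compound 3 `CS(=O)(=O)c1cnc(Nc2ccc(O)cc2)nc1NCc1ccccc1` gives 5 mL.min-1.g-1, a gap to compound 1 that lies beyond the scatter. Going by the values given here, compound 1 therefore has the highest of the three numbers, though its separation from compound 2 is not meaningful, and the three compounds share no single core, so no step between them is counted.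

The next compound, compound 4 `CNC(=O)c1sc(N2CC3CC2(CNC(=O)c2c[nH]c4ncc(Cl)cc24)C3)nc1C(F)(F)F`, differs from compound 1 in one place: chloro in place of trifluoromethyl on an aromatic carbon. Nothing among the three measured compounds shows how this exchange moves the read-out. Among the compounds with values here, with no step of this kind to draw on, the expectation for the move from compound 1 to compound 4 is a 1.1-fold lower number from compound 1 to compound 4 (0.03 log units; within the scatter), a step not beyond the scatter. Compound 4 is accordingly estimated at 120 mL.min-1.g-1, with a range from 60 mL.min-1.g-1 to 240 mL.min-1.g-1.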

Compound 4, intrinsic clearance in microsomes: > 300 mL.min-1.g-1
Compound 4 ended at the assay's limit (the forecaster's own chance of this, stated with the estimate: 5%); middle value at least 2.5-fold (0.39 log units) from the limit.
By their numbers in this assay, from the lowest: compound 3; then compounds 2 and 1 (each within the scatter of the next). At a limit, above all of these: compound 4.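

In this assay, the substituent on this aromatic carbon of the six-membered aromatic ring with 1 nitrogen proves not to be a neutral choice: chloro in place of trifluoromethyl gives an at least 2.3-fold higher number from compound 1 to compound 4 (0.36 log units; beyond the scatter). Compound 4 reads > 300 mL.min-1.g-1, a limit of the assay and not a number. The true size of the step therefore stays unknown, and only its minimum can be read: the limit of > 300 mL.min-1.g-1 in this assay, at which 1 of the 4 values shown sits.

On these data alone, whether a nitrile, a methoxy group or plain hydrogen on the same aromatic carbon would keep the read-out near that of compound 1 or take it to the limit with compound 4 remains open. Also open, as far as these compounds go, is whether this exchange moves the read-out the same way on another core, as the step rests on a single pair.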